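Bromo to methoxy: working notes on compound 3

This account rests on a few compounds, and the source may have more. Where it says the series, first, only, none or still open, it means among the compounds named here.

Values in a functional assay on AGS cells (Homo sapiens) for antiproliferative activity, read by MTT assay, with a stated time of 48 h; a lower number here means a stronger inhibitor of growth, a higher number a weaker inhibitor of growth:
- compound 1 `COc1ccccc1OCCNc1ccc(=O)n(Cc2ccc(OC)c(OCC3CC3)c2)n1`: 45800 nM
- compound 2 `COc1ccc(Cn2nc(NCCOc3ccccc3OC)ccc2=O)cc1Br`: > 100000 nM (a limit, not a number)

Compound 2 is known only through a limit, namely (the limit of > 100000 nM in this assay, at which 1 of the 2 values shown sits). Its true position is therefore open, and no number can be assigned to it.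

The next structure is compound 3 `COc1ccc(Cn2nc(NCCOc3ccccc3OC)ccc2=O)cc1OC`, with methoxy in place of bromo on an aromatic carbon. This is the change from 3-bromo-4-methoxyphenyl to 3,4-dimethoxyphenyl.

Among the compounds with values here, one measured step bears on this change: an at least 2.1-fold higher number from compound 1 to compound 2 (0.33 log units; beyond the scatter). As far as these compounds go, that step has bromo in place of cyclopropylmethoxy on an aromatic carbon, and its full size is unknown. Compound 3 has no bromo and carries methoxy where compound 1 carries cyclopropylmethoxy, so a value near that of compound 1 at 45800 nM is expected. This rests on a single step.

The step expected in this assay is an at least 2.0-fold lower number from compound 2 to compound 3 (0.30 log units; that floor lies within the scatter), towards a lower number, although another reading at the limit remains possible. For compound 3 the estimate is 50000 nM, with an expected range from 22000 nM to 100000 nM.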

Compound 3, concentration for 50% growth inhibition: > 100000 nM
Compound 3: a limit, no number; the forecaster's own chance of this, stated with the estimate: 30%; middle value at least 2.0-fold (0.30 log units) away from the limit.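

In this assay compound 3 gives > 100000 nM, which is a limit and not a number. With bromo gone, the result is an at least 2.1-fold higher number from compound 1 to compound 3 (0.33 log units; beyond the scatter), so the shift from compound 1 does not need bromo: the cyclopropyl of cyclopropylmethoxy, replaced here by hydrogen, is by itself enough to produce a step beyond the scatter. The step between bromo and methoxy cannot be read because compound 2 and compound 3 sit at the same limit: the limit of > 100000 nM in this assay, at which 2 of the 3 values shown sit.

Among the three compounds, only compound 1 has a measured number, so the true positions of compound 2 and compound 3, and any order between them, stay open. The compounds shown also do not tell whether a longer chain, such as cyclobutylmethoxy, or an amine or a carboxylic acid at the end of the chain at this position would keep or improve the growth inhibition of compound 1.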